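The source may report more compounds than this note shows. Statements on the series, on what has been measured and on what is new or still open speak of the compounds shown alone.

Three compounds have a measured value. In a functional assay on A549 cells (Homo sapiens) for antiproliferative activity, read by MTT assay, with a stated time of 72 h (on this read-out lower numbers stand for stronger inhibition and higher numbers for weaker inhibition), compound 1, `COc1cc2ncnc(Nc3cccc(Br)c3)c2cc1OCCCCC(=O)Nc1ccc(S(N)(=O)=O)cc1`, gives 14900 nM. Compound 2, `COc1cc2ncnc(Nc3cccc(Cl)c3)c2cc1OCCCCC(=O)Nc1ccc(S(N)(=O)=O)cc1`, gives 11200 nM in this assay. Compound 3, `COc1cc2ncnc(Nc3cccc(F)c3)c2cc1OCCCCC(=O)Nc1ccc(S(N)(=O)=O)cc1`, reaches only a limit of this assay, > 40000 nM.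

Compound 2 carries the lowest of the two numbers shown, and its nearest neighbour is compound 1: a 1.3-fold lower number from compound 1 to compound 2 (0.12 log units; within the scatter). The third value is a limit, (the limit of > 40000 nM in this assay, at which 1 of the 3 values shown sits). Against that limit the steps from the two halogen compounds are larger: an at least 2.6-fold higher number from compound 1 to compound 3 (0.42 log units; beyond the scatter), and an at least 3.5-fold higher number from compound 2 to compound 3 (0.55 log units; beyond the scatter).

Compound 4, `COc1ccc(Nc2ncnc3cc(OC)c(OCCCCC(=O)Nc4ccc(S(N)(=O)=O)cc4)cc23)cc1`, is not yet measured. Its difference from compound 2 is 4-methoxyphenyl in place of 3-chlorophenyl on a nitrogen on an aromatic ring. Every measured step changes the same ring, but each one only exchanges one halogen for another; none replaces a halogen by a methoxy group, and none moves a substituent from one place on that ring to another. What the measured steps do show is that a change on this ring can leave the number in place or push it out to the limit, and never pulled it down. Compound 4 is therefore expected to sit at a higher number than compound 2, with a real chance of reaching the limit, a 2.7-fold higher number from compound 2 to compound 4 (0.43 log units; beyond the scatter). The estimate for compound 4 is 30000 nM, between 9000 nM and 100000 nM.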

Compound 4, half-maximal inhibitory concentration: > 40000 nM
Compound 4 gave a limit, no number; the forecaster's own chance of this, stated with the estimate: 40%; middle value at least 1.3-fold (0.12 log units) away from the limit.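

In this assay, within the data shown here, the earlier steps only exchanged one halogen for another, whereas this one replaces the halogen-bearing 3-chlorophenyl by 4-methoxyphenyl on a nitrogen on an aromatic ring, and it shows that a non-halogen group here also moves the result well away from the two compounds that give numbers: an at least 3.5-fold higher number from compound 2 to compound 4 (0.55 log units; beyond the scatter), and an at least 2.6-fold higher number from compound 1 to compound 4 (0.42 log units; beyond the scatter). Compound 4 gives only a limit, > 40000 nM, so the size of both steps is known only as a minimum. The step between compound 3 and compound 4 cannot be read, as both values are limits, and among the four compounds only compound 1 and compound 2 now keep a number, with compound 3 and compound 4 standing apart from them: the limit of > 40000 nM in this assay, at which 2 of the 4 values shown sit.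

This single step changes both the group and its place on the ring, and the compounds shown do not separate those two changes. From the compounds shown here alone, whether an unsubstituted phenyl ring, or an amine or a carboxylic acid on that ring, would give a number in this assay also stays open.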